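Adding methoxy to compound 1: what to expect

The source may report more compounds than this note shows. Statements on the series, on what has been measured and on what is new or still open speak of the compounds shown alone.

In a physicochemical assay for pharmacokinetics, read by HPLC, at pH 7.5, tested at 250 uM (on this read-out lower numbers stand for a shorter-lived compound and higher numbers for a longer-lived compound), compound 1 `CN(C)CC1Cc2ccccc2C1=O` gives 0.167 h. Compound 3 `CN(C)CC1Cc2cc(Br)ccc2C1=O` gives 0.1 h, a reading within the scatter of compound 1, while compound 2 `CN(C)CC1Cc2c(cccc2C(F)(F)F)C1=O` gives 28.9 h, far from both. Compound 1 therefore sits at the low end of this small set, level with compound 3.

Compound 4 `COc1ccc2c(c1)C(=O)C(CN(C)C)C2` has not yet been measured. It carries one change to the core of compound 1: methoxy in place of hydrogen on an aromatic carbon. Put simply, this is methoxy in place of hydrogen on an aromatic carbon.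

Among the measured compounds shown here, two measured steps bear on this change, since each also replaces a hydrogen on an aromatic carbon, though neither introduces methoxy. The bromo step, a 1.7-fold lower number from compound 1 to compound 3 (0.22 log units; within the scatter), stays within the scatter. The trifluoromethyl step, a 170-fold higher number from compound 1 to compound 2 (2.24 log units; beyond the scatter), is large. For the measured compounds named here, these two precedents disagree, and no measured compound carries methoxy, so the forecast is uncertain. Going by the values given here, with only one large step in the set, the expectation in this assay is for no change beyond the scatter, though a longer half-life remains possible. The estimated step is small: a 1.2-fold higher number from compound 1 to compound 4 (0.08 log units; within the scatter). Compound 4 is estimated at 0.2 h, with an expected range from 0.06 h to 1.5 h.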

Compound 4, half-life: 0.2 h
Compound 4: the middle estimate sits on the measured number at the digits printed, within the range that was stated.
By their numbers in this assay, from the lowest: compounds 3, 1 and 4 (each within the scatter of the next); then compound 2.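

In this assay the methoxy change gives a 1.2-fold higher number from compound 1 to compound 4 (0.08 log units; within the scatter) and so leaves the reading of compound 1 in place, at this aromatic carbon that is meta to a fused ring and para to a fused ring. Methoxy now joins bromo among the replacements of an aromatic hydrogen that stay within the scatter, while the step of a 170-fold higher number from compound 1 to compound 2 (2.24 log units; beyond the scatter) remains the only large one of the three, so adding atoms to this aromatic ring does not by itself go with a long half-life in these compounds. Nothing measured here explains why the trifluoromethyl step stands apart from the other two.

Still open, from the compounds shown here alone, is how methoxy would read on the aromatic carbon that carries trifluoromethyl in compound 2, which would separate the effect of the group from that of its place on the ring. Also open, going by these compounds, is how a nitrile, an amine or a carboxylic acid would read on the carbon that carries methoxy in compound 4, and whether a longer chain such as ethoxy would stay within the scatter of compound 1.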